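The source may hold more compounds than are shown below. What is called first, only, known or untested is meant among the compounds shown, and "the series" means these compounds.

Compound 1 `O=C(CSC(=S)N[C@H]1CCOC1=O)Nc1cccc(C(F)(F)F)c1` in a functional assay on SMMC-7721 cells (Homo sapiens) for cytotoxicity, read by MTT assay, with a stated time of 72 h (on this read-out lower numbers stand for stronger inhibition and higher numbers for weaker inhibition), gives > 128000 nM, which is a limit of the assay and not a number (the limit of > 128000 nM in this assay, at which 1 of the 2 values shown sits). Among the measured compounds shown here, compound 2 `O=C(CCl)Nc1ccc(C(=O)/C=C/c2ccccc2)cc1` in this assay gives 12600 nM, the only number obtained so far. Compound 3 `O=C(CCl)Nc1ccc(C(=O)/C=C/c2ccc(F)cc2)cc1` differs from compound 2 by fluoro in place of hydrogen on an aromatic carbon. For the measured compounds named here, no measured pair of this kind exists here, so the step from compound 2 to compound 3 in this assay is expected to stay within the usual scatter, with no direction claimed. Compound 3 is estimated at 10000 nM, between 4000 nM and 30000 nM, which means an expected step of a 1.3-fold lower number from compound 2 to compound 3 (0.10 log units; within the scatter).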

Compound 3, half-maximal inhibitory concentration: 15100 nM
Compound 3: the middle estimate sits 1.5-fold (0.18 log units) below what was measured, within the range that was stated.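

In this assay, among the compounds shown here, the change from phenyl to 4-fluorophenyl gives a 1.2-fold higher number from compound 2 to compound 3 (0.08 log units; within the scatter), the first step that can be read. At this position, on an aromatic carbon para to a large group, fluoro in place of hydrogen therefore leaves the read-out within the scatter. No result shown bears on a cause for this step.

As far as these compounds go, whether an amine or a carboxylic acid on the same aromatic carbon would give a step beyond the scatter remains open. Steps to compound 1 cannot be read, since it differs from the others in more than one place.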